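The compounds below may be only part of what the source reports. "The series", "measured", "known", "first", "only" and "open" are said of these compounds alone.

In a functional assay on A549 cells (Homo sapiens) for antiproliferative activity, read by MTT assay, with a stated time of 48 h (on this read-out higher numbers stand for weaker inhibition and lower numbers for stronger inhibition), three compounds sharing one core have been measured. Compound 1 (`CC(=O)OC/C1=C/C[C@](C)(CCC=C(C)C)/C=C/[C@@H](OC(=O)C=C(C)C)[C@](C)(O)/C=C/C1=O`), with an acetoxymethyl group on a double-bonded ring carbon, gives 2950 nM in this test. Compound 2 (`CC(C)=CCC[C@]1(C)/C=C/[C@@H](OC(=O)C=C(C)C)[C@](C)(O)/C=C/C(=O)/C(C(=O)O)=C\C1`), with carboxy in that place, reads > 10000 nM and this value is a limit of the assay, not a number. Compound 3 (`CC(C)=CCC[C@]1(C)/C=C/[C@@H](OC(=O)C=C(C)C)[C@](C)(O)/C=C/C(=O)/C(CN2CCCC2)=C\C1`), with (pyrrolidin-1-yl)methyl there, gives 180 nM as the lowest number of the three, which means the strongest inhibition.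

Compound 4 (`CC(C)=CCC[C@]1(C)/C=C/[C@@H](OC(=O)C=C(C)C)[C@](C)(O)/C=C/C(=O)/C(CN=[N+]=[N-])=C\C1`) has not been measured yet. It departs from compound 3 in one group: azido in place of pyrrolidin-1-yl on a saturated chain carbon bound to a double-bonded ring carbon.

The measured step closest to this change is a 16-fold lower number from compound 1 to compound 3 (1.21 log units; beyond the scatter), since it swaps a group on that same carbon. A wider comparison at this place is an at least 55-fold lower number from compound 2 to compound 3 (1.74 log units; beyond the scatter), but that limit-based step replaces more of the molecule. Both steps favour the pyrrolidin-1-yl compound, and azido, like the acetoxy of compound 1, carries no ring. Part of the gain is therefore expected to be lost, though azido has never been tested here, so the expected change is a 6.7-fold higher number from compound 3 to compound 4 (0.82 log units; beyond the scatter) and is a rise of clear size. The estimate for compound 4 is 1200 nM with an expected range (350 nM to 4000 nM).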

Compound 4, half-maximal inhibitory concentration: 1720 nM
The estimate for compound 4 lay 1.4-fold (0.16 log units) below the measured number, within the range that was stated.
By their numbers in this assay, from the lowest: compound 3; then compounds 4 and 1 (each within the scatter of the next). At a limit, above all of these: compound 2.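

In this assay, the step of a 9.6-fold higher number from compound 3 to compound 4 (0.98 log units; beyond the scatter) shows that the large gain of pyrrolidin-1-yl over acetoxy on this saturated chain carbon does not carry over to azido, a second group with no ring. Compound 4 and compound 1 cannot be separated, with a 1.7-fold lower number from compound 1 to compound 4 (0.23 log units; within the scatter), so among the three groups shown at this carbon, only pyrrolidin-1-yl stands apart, and swapping acetoxy for azido gives no readable change. Going by these compounds, replacing carboxy with azidomethyl on the double-bonded ring carbon gives an at least 5.8-fold lower number from compound 2 to compound 4 (0.76 log units; beyond the scatter), but this step starts from a limit of the assay and not a number, so its true size stays unknown: the limit of > 10000 nM in this assay, at which 1 of the 4 values shown sits.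

Pyrrolidin-1-yl differs from both azido and acetoxy in being a ring and in being an amine, and these compounds cannot show which of the two features goes with the low number of compound 3. An open-chain amine such as dimethylamino and a different ring such as piperidin-1-yl or morpholin-4-yl on the same carbon would remain the informative comparisons.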